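The source may report more compounds than this note shows. Statements on the series, on what has been measured and on what is new or still open speak of the compounds shown alone.

Of the compounds shown here, two have been measured in an assay on isolated protein for inhibition of Amine oxidase [flavin-containing] B (Homo sapiens), read by fluorescence and spectrophotometry; a higher number here means a weaker inhibitor, a lower number a stronger inhibitor. Compound 1 `Cc1ccc(C(=O)NCc2cn(Cc3ccc4oc(-c5ccc(Cl)cc5)cc(=O)c4c3)nn2)cc1`, which carries a chloro on the phenyl of its core, gives 32900 nM. Compound 2 `O=C(CCc1cn(Cc2ccc3oc(-c4ccccc4)cc(=O)c3c2)nn1)Nc1ccc(Cl)cc1`, with an unsubstituted phenyl on the core and a different amide arm, gives 15600 nM, the lower of the two numbers, and the gap between the two lies beyond the scatter; the two differ in more than one place, so the two values say nothing about either change alone.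

The step under consideration leads from compound 2 to compound 3 `O=C(CCc1cn(Cc2ccc3oc(-c4ccc(Cl)cc4)cc(=O)c3c2)nn1)Nc1ccc(Cl)cc1`. The change is chloro in place of hydrogen on an aromatic carbon, on an aromatic carbon of a six-membered aromatic ring of carbon only. Among the compounds with values here, no measured pair isolates this change, so no direction can be read off. For this assay a small step, within the scatter, is expected, a 1.3-fold lower number from compound 2 to compound 3 (0.11 log units; within the scatter). Compound 3 is therefore estimated at 12000 nM, with a range from 5000 nM to 30000 nM.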

Compound 3, half-maximal inhibitory concentration: 32900 nM
Estimate against measurement, compound 3: 2.7-fold (0.44 log units) below; measured number above the stated range.
By their numbers in this assay, from the lowest: compound 2; then compounds 1 and 3 (each within the scatter of the next).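

Phenyl to 4-chlorophenyl on the core now has its first isolated reading: in this assay the step is a 2.1-fold higher number from compound 2 to compound 3 (0.32 log units; beyond the scatter), so the chloro on this aromatic carbon, para to a large group, goes with a modest loss in this pair. With the 4-chlorophenyl held constant, the change of arm gives no change at the digits printed from compound 1 to compound 3 (within the scatter), so the arms of compound 1 and compound 3 are not told apart in this assay. The gap between compound 1 and compound 2, which could not be assigned earlier, therefore fits the chloro step in this small set.

Going by these compounds, whether a methoxy group or a carboxylic acid at this position, or a longer chain in the arm, would move the number remains open. No measurement at hand bears on the reason for the chloro step.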